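Amide variation on the pyridinyl piperidine series

The source may hold more compounds than are shown below. What is called first, only, known or untested is meant among the compounds shown, and "the series" means these compounds.

Compound 1 `CN1CCC(c2c[nH]c3cnc(NC(=O)c4ccc(F)cc4)cc23)CC1`: 53 nM
Compound 2 `CC(=O)Nc1cc2c(C3CCN(C)CC3)c[nH]c2cn1`: 39 nM
Compound 3 `CN1CCC(c2c[nH]c3ccc(NC(=O)C4CC4)nc23)CC1`: 1800 nM

Of the compounds shown here, three have been measured in an assay for binding affinity to 5-hydroxytryptamine receptor 1D (Homo sapiens), read by radioligand binding; a higher number here means a weaker inhibitor, a lower number a stronger inhibitor. Compound 3 stands highest of the three numbers: compound 1 comes nearest and compound 2 lies furthest, and both gaps are beyond the scatter. Compound 3 also carries a core distinct from the shared core of compounds 1 and 2, so the two pairs are not directly comparable in that respect.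

Compound 4 `Cc1cccc(C(=O)Nc2ccc3[nH]cc(C4CCN(C)CC4)c3n2)c1` has not yet been measured. It differs from compound 3 in one place: 3-methylphenyl in place of cyclopropyl on a carbonyl carbon. Going by the values given here, the only measured step that bears on a change at that carbonyl carbon is a 1.4-fold lower number from compound 1 to compound 2 (0.13 log units; within the scatter), where an aryl amide and a small alkyl amide gave numbers within the scatter of each other. Nothing measured separates cyclopropyl from a methylphenyl group, and nothing tests an amide swap on the core of compound 3. The expectation is therefore a small step, if any, and the sign is uncertain.

Compound 4 is expected to give 1200 nM, with a range from 350 nM to 4000 nM. The step this estimate implies, a 1.5-fold lower number from compound 3 to compound 4 (0.18 log units; within the scatter), is expected to fall within the scatter.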

Compound 4, inhibition constant: 490 nM
Compound 4: the middle estimate sits 2.4-fold (0.39 log units) above what was measured; measured number inside the range.
By their numbers in this assay, from the lowest: compounds 2 and 1 (each within the scatter of the next); then compound 4; then compound 3.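

On the core of compound 3, the group on the carbonyl carbon does register in this assay: 3-methylphenyl in place of cyclopropyl gives a 3.7-fold lower number from compound 3 to compound 4 (0.57 log units; beyond the scatter), a modest step and the first one at this carbonyl carbon to lie beyond the scatter. Going by these compounds alone, the only earlier step at this carbonyl carbon, a 1.4-fold lower number from compound 1 to compound 2 (0.13 log units; within the scatter), lay within the scatter, but it exchanged a different pair of groups on a different core, so the two steps cannot show whether the core alters the effect of a change here. No evidence at hand accounts for the step from cyclopropyl to 3-methylphenyl.

The compounds shown leave open whether the gain on the core of compound 3 needs the methyl group at all, or whether an unsubstituted phenyl, a 4-fluorophenyl or a simple methyl on the same carbonyl carbon would give a similar number. They also leave open how a longer chain such as butyl would read on this core, and so whether the aromatic ring or merely a larger group goes with the lower number.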